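Halogen Walk at the Fused Ring: Fluoro, Chloro, Bromo

The source may report more compounds than this note shows. Statements on the series, on what has been measured and on what is new or still open speak of the compounds shown alone.

Measured so far:
- compound 1, `Cc1nc(N=C(N)N)nc2ccc(F)cc12`: 145 nM
- compound 2, `Cc1nc(N=C(N)N)nc2ccc(Cl)cc12`: 630 nM

In an assay on isolated protein for inhibition of Myeloperoxidase (Homo sapiens), with a stated time of 5 min (on this read-out higher numbers stand for weaker inhibition and lower numbers for stronger inhibition), compound 1 gives 145 nM and compound 2 gives 630 nM. Going by the values given here, on these two numbers compound 2 stands highest, the only other point being compound 1, which lies lower by the one measured step, a 4.3-fold higher number from compound 1 to compound 2 (0.64 log units; beyond the scatter).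

Compound 3, `Cc1nc(N=C(N)N)nc2ccc(Br)cc12`, is not yet measured. It differs from compound 2 by bromo in place of chloro on an aromatic carbon. Among the compounds with values here, the only step that bears on this change is the exchange of the same position from fluoro to chloro, a 4.3-fold higher number from compound 1 to compound 2 (0.64 log units; beyond the scatter), a modest step beyond the scatter towards weaker inhibition. Nothing in the series shows what a second halogen exchange at this site does; the step from chloro to bromo is expected to be smaller than that one, in the same direction or within the scatter.

For compound 3 a number of 1000 nM is estimated in this assay, with a range from 400 nM to 2500 nM, which means an expected step of a 1.6-fold higher number from compound 2 to compound 3 (0.20 log units; within the scatter).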

Compound 3, half-maximal inhibitory concentration: 756 nM
Compound 3: middle estimate off by 1.3-fold (0.12 log units), on the high side, and the stated range covers the measured number.
By their numbers in this assay, from the lowest: compound 1; then compounds 2 and 3 (each within the scatter of the next).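

In this assay the exchange of chloro for bromo gives a 1.2-fold higher number from compound 2 to compound 3 (0.08 log units; within the scatter) on this aromatic carbon, while the exchange of fluoro for bromo gives a 5.2-fold higher number from compound 1 to compound 3 (0.72 log units; beyond the scatter) on the same carbon. The halogens shown therefore fall into two groups: fluoro in compound 1 stands apart with the lowest number, while chloro and bromo cannot be told apart on this read-out, which the single step from fluoro to chloro could not show. Nothing measured here accounts for this split among the halogens.

From the compounds shown here alone, what a group other than a halogen does on this carbon stays open, for instance an amine, a methoxy group or a nitrile. Also open, going by these compounds, is how plain hydrogen at this place compares with fluoro in compound 1.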